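Arylidene thiazolidinone series: cytotoxicity working notes

This account rests on a few compounds, and the source may have more. Where it says the series, first, only, none or still open, it means among the compounds named here.

Compound 1 `Cc1ccc(-c2cc(/N=C3/NC(=O)CS3)cs2)cc1` reaches only the limit > 50000 nM in a functional assay on HT-29 cells (Homo sapiens) for cytotoxicity, read by MTT assay, with a stated time of 72 h (on this read-out lower numbers stand for stronger inhibition and higher numbers for weaker inhibition), a limit of the assay.
Compound 2 `O=C1CS/C(=N\c2csc(-c3ccc(Cl)cc3)c2)N1` gives 17100 nM in this assay.
Compound 3 `CN(C)c1ccc(/C=C2\S/C(=N\c3csc(-c4ccc(Cl)cc4)c3)NC2=O)cc1` gives 1500 nM in this assay.

Compound 3 stands lowest of the two numbers; compound 2 is nearest, with a higher number that lies beyond the scatter. Within the data shown here, the only measured step, an at least 2.9-fold lower number from compound 1 to compound 2 (0.46 log units; beyond the scatter), concerns the other aryl ring and so does not bear on the present change. Compound 4 `O=C1N/C(=N/c2csc(-c3ccc(Cl)cc3)c2)S/C1=C\c1ccc(F)cc1` differs from compound 3 by fluoro in place of dimethylamino on an aromatic carbon. Among the measured compounds shown here, with no measured step speaking to this change, a modest loss beyond the scatter is estimated, a 2.3-fold higher number from compound 3 to compound 4 (0.37 log units; beyond the scatter). Compound 4 is therefore expected at 3500 nM, between 1000 nM and 12000 nM.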

Compound 4, half-maximal inhibitory concentration: 4100 nM
Compound 4: middle estimate off by 1.2-fold (0.07 log units), on the low side, within the range that was stated.
By their numbers in this assay, from the lowest: compound 3; then compound 4; then compound 2. At a limit, above all of these: compound 1.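

Among these compounds, the change from 4-(dimethylamino)phenyl to 4-fluorophenyl gives a 2.7-fold higher number from compound 3 to compound 4 (0.44 log units; beyond the scatter) in this assay, the first measured step at this position. The position therefore responds to its substituent, but the swap of dimethylamino for fluoro costs only a modest step, and activity in the low range of this series is kept with either group. Nothing measured in the series accounts for the size of this step.

With only these two groups at this position, no trend can be drawn from it. As far as these compounds go, whether a primary amine, a methoxy group or a carboxylic acid there would give a lower or higher number stays open.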